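A Ring Swap on a Urea-Linked Scaffold in Lung Cancer Cells

This account rests on a few compounds, and the source may have more. Where it says the series, first, only, none or still open, it means among the compounds named here.

Measured so far, in a functional assay on NCI-H1581 cells (Homo sapiens) for inhibition, read by MTT assay, with a stated time of 48 h, tested at 10 uM; a higher number here means more inhibition at the concentration tested (going by the name of the read-out), a lower number less inhibition:
compound 1, `COc1cc(NC(=O)Nc2cc(Nc3ccc(OC)c(C)c3)ncn2)cc(OC)c1`, gives 19.7%
compound 2, `CCc1cccc(Nc2cc(NC(=O)Nc3cc(OC)cc(OC)c3)ncn2)c1`, gives 27.7%
compound 3, `COc1cc(NC(=O)Nc2cc(Nc3ccc(C(C)(C)C)cc3)ncn2)cc(OC)c1`, gives 38.7%

All three share the same core and differ only in the ring carried on a nitrogen of that core. Compound 3 stands highest of the three: a number 11 percentage points higher from compound 2 to compound 3 (beyond the scatter), and a number 19 percentage points higher from compound 1 to compound 3 (beyond the scatter). The step of a number 8 percentage points higher from compound 1 to compound 2 (within the scatter) is small.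

Compound 4, `COc1cc(NC(=O)Nc2cc(Nc3cc(F)ccc3OC)ncn2)cc(OC)c1`, has not yet been measured in this assay. Its change from compound 3: 5-fluoro-2-methoxyphenyl in place of 4-(tert-butyl)phenyl on a nitrogen on an aromatic ring.

For the measured compounds named here, the step that bears most on this is the one from compound 1 to compound 3, where a methoxy-bearing ring was exchanged for the 4-(tert-butyl)phenyl ring and the number rose beyond the scatter. Compound 4 returns a methoxy-bearing ring, so a drop back toward the level of compound 1 is expected, a step of a number 14.7 percentage points lower from compound 3 to compound 4 (beyond the scatter). For compound 4, a value of 24% is estimated, expected to fall between 10% and 40%.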

Compound 4, a percentage reported as inhibition, at one concentration (the size of the read-out at that concentration, not a potency): 42.1%
Compound 4: the middle estimate sits 18.1 percentage points below what was measured, and the stated range ends below it.
By their numbers in this assay, from the lowest: compounds 1 and 2 (each within the scatter of the next); then compounds 3 and 4 (each within the scatter of the next).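

In this assay a methoxy group on the ring attached to this nitrogen does not by itself hold the number down: exchanging 4-(tert-butyl)phenyl for 5-fluoro-2-methoxyphenyl gives a number 3.4 percentage points higher from compound 3 to compound 4 (within the scatter) and so leaves the two rings indistinguishable here. The same ring also gives a number 14.4 percentage points higher from compound 2 to compound 4 (beyond the scatter) and a number 22.4 percentage points higher from compound 1 to compound 4 (beyond the scatter) in comparison with the other two rings, which shows that two methoxy-bearing rings, those of compound 1 and compound 4, can sit well apart. No measurement at hand accounts for this difference.

On these data alone, it remains open whether the fluorine or the methoxy group of compound 4 matters more, or whether only the two together give this number. Also open, as far as these compounds go, is what an amine or a carboxylic acid on this ring would give.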